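The compounds below may be only part of what the source reports. "The series", "measured", "known", "first", "only" and "open" are said of these compounds alone.

Compound 2 `CCCCNc1nc(N2CC(=O)Nc3cc(OC)ccc32)c2ccccc2n1` sits highest of the three measured compounds in a physicochemical assay for lipophilicity, read by HPLC, measured as octanol-water partition, tested at 1 mg/mL (a lower number here means a more polar compound, a higher number a more lipophilic compound), where compound 2 gives 3.91. The nearest measured number belongs to compound 3 `COc1ccc2c(c1)NC(=O)CN2c1nc(COC(C)=O)nc2ccccc12`, which in this assay gives 2.7; the step is a number 1.21 log units lower from compound 2 to compound 3 (beyond the scatter). Furthest away is compound 1 `COc1ccc2c(c1)NC(=O)CN2c1nc(NCCCO)nc2ccccc12`, which in this assay gives 2.6; the step from it is a number 1.31 log units higher from compound 1 to compound 2 (beyond the scatter). Between the two lower compounds the step is a number 0.10 log units higher from compound 1 to compound 3 (within the scatter).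

Compound 4 `COc1ccc2c(c1)NC(=O)CN2c1nc(NC2CCCC2)nc2ccccc12` differs from compound 2 in one place: cyclopentyl in place of butyl on a nitrogen on an aromatic ring. Within the data shown here, none of the three measured steps bears directly on this change; each of them swaps a hydroxy, an amino group or a whole substituent on the aromatic carbon, and no measured step trades a chain for a ring of the same kind. The expectation for compound 4 therefore rests on the value of compound 2 alone, and a step within the scatter, a number 0.04 log units higher from compound 2 to compound 4 (within the scatter), is expected. Compound 4 is estimated at 3.95, within a range from 3.6 to 4.3.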

Compound 4, partition coefficient: 2.33
For compound 4 the middle estimate is 1.62 log units above the measured one, and the stated range ends above it.
By their numbers in this assay, from the lowest: compounds 4, 1 and 3 (each within the scatter of the next, the first and the last beyond it); then compound 2.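

On the nitrogen on an aromatic ring, cyclopentyl in place of butyl proves a far from neutral exchange in this assay (a number 1.58 log units lower from compound 2 to compound 4 (beyond the scatter)), the largest step among the four compounds. Set against the 3-hydroxypropyl group at the same place, cyclopentyl cannot be told apart (a number 0.27 log units lower from compound 1 to compound 4 (within the scatter)), so on this nitrogen compound 2 stands alone, and the absence of a hydroxy group does not by itself go with a high number. Cyclopentylamino on the aromatic carbon also gives a modest separation from acetoxymethyl (a number 0.37 log units lower from compound 3 to compound 4 (beyond the scatter)).

Whether the step follows the ring or the extra carbon stays open, as neither a pentyl chain nor a cyclobutyl group on this nitrogen is among the compounds shown. Nothing available accounts for the size of this step.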